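The source may hold more compounds than are shown below. What is called first, only, known or untested is meant among the compounds shown, and "the series" means these compounds.

The measured compounds are:

compound 1, `Cc1ccccc1-n1cc(-c2ccccc2NS(=O)(=O)c2c[nH]c(=O)[nH]c2=O)nn1`, 3210 nM;
compound 2, `Cc1cccc(-n2cc(-c3ccccc3NS(=O)(=O)c3c[nH]c(=O)[nH]c3=O)nn2)c1`, 1870 nM;
compound 3, `Cc1ccccc1-n1cc(-c2ccc(NS(=O)(=O)c3c[nH]c(=O)[nH]c3=O)cc2)nn1`, 3130 nM.

Going by the values given here, in a functional assay on A549 cells (Homo sapiens) for antiproliferative activity, read by MTT assay, with a stated time of 24 h (a lower number here means a stronger inhibitor, a higher number a weaker inhibitor), the only single change that has been measured is 3-methylphenyl in place of 2-methylphenyl on an aromatic nitrogen, which gave a 1.7-fold lower number from compound 1 to compound 2 (0.23 log units; within the scatter). Compound 3 shares a core with compound 1 but the difference between the two cores is not broken down here; what the two values show is that compound 3 and compound 1 lie within the scatter of each other in this assay.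

Compound 4, `Cc1cccc(-n2cc(-c3ccc(NS(=O)(=O)c4c[nH]c(=O)[nH]c4=O)cc3)nn2)c1`, has not yet been measured. It differs from compound 3 by 3-methylphenyl in place of 2-methylphenyl on an aromatic nitrogen, and the surroundings of the place are described in the same words as for the change from compound 1 to compound 2, so it is the same change made on the core of compound 3. On that basis compound 4 is expected to move from compound 3 by about a 1.6-fold lower number from compound 3 to compound 4 (0.22 log units; within the scatter), because the same change gave a 1.7-fold lower number from compound 1 to compound 2 (0.23 log units; within the scatter), a step within the scatter. Compound 4 is therefore estimated at 1900 nM in this assay, with the range 900 nM to 4000 nM.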

Compound 4, half-maximal inhibitory concentration: 6960 nM
For compound 4 the middle estimate is 3.7-fold (0.56 log units) below the measured one; measured number above the stated range.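

In this assay, 3-methylphenyl in place of 2-methylphenyl on the core of compound 3 gave a 2.2-fold higher number from compound 3 to compound 4 (0.35 log units; beyond the scatter), so the change did not carry over as a constant step from the core of compound 1. The two cores differ in their response to this one change by more than the scatter of two such steps: the same change on two cores in this assay, a 1.7-fold lower number (0.23 log units; within the scatter) from compound 1 to compound 2 and a 2.2-fold higher number (0.35 log units; beyond the scatter) from compound 3 to compound 4, 3.8-fold (0.58 log units) apart, beyond the scatter of two such steps. This shows that in this series a step measured on one core cannot simply be transferred to the other, but it does not show what in the cores sets the difference. The earlier step lies within the scatter. It does not establish a true reversal of direction.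

The compounds shown leave open whether this dependence on the core extends to other groups on the aromatic nitrogen. A plain phenyl, or a phenyl carrying a methoxy group or a chlorine in place of the methyl, could show whether the two cores part in the same way.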